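Working notes: butyl for phenylsulfonyl on the terminal amide

This account rests on a few compounds, and the source may have more. Where it says the series, first, only, none or still open, it means among the compounds named here.

Measured so far:
compound 1, `CC[C@H](C)[C@H](NC(=O)c1cccc(Cn2ccnc2)c1)C(=O)NNS(=O)(=O)c1ccccc1`: 6%
compound 2, `CC[C@H](C)[C@H](NC(=O)c1cccc(Cn2ccnc2)c1)C(=O)NS(=O)(=O)c1ccccc1`: 5%
compound 3, `CCCCCS(=O)(=O)NNC(=O)[C@@H](NC(=O)c1cccc(Cn2ccnc2)c1)[C@@H](C)CC`: "not determined" (no result reported)

In an assay on HEK293 cells for displacement of a labelled ligand from Type-2 angiotensin II receptor (Homo sapiens), tested at 1 uM (on this read-out lower numbers stand for a weaker effect and higher numbers for a stronger effect at the one concentration tested), compound 1 gives 6% and compound 2 gives 5%. Compound 2 has the lower of the two numbers, but the step of a number 1 percentage points lower from compound 1 to compound 2 (within the scatter) lies within the scatter, so the two cannot be ordered. In this assay compound 3 gives "not determined" (no result reported) and so contributes no number.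

Compound 4 is `CCCCNC(=O)[C@@H](NC(=O)c1cccc(Cn2ccnc2)c1)[C@@H](C)CC`. Relative to compound 2 the change is butyl in place of phenylsulfonyl on an amide-type nitrogen. Going by the values given here, no measured step concerns this exchange; the only step in hand, a number 1 percentage points lower from compound 1 to compound 2 (within the scatter), addresses a different change and stayed within the scatter. Nothing in the numbers therefore points to a step beyond the scatter, and the step expected is a number 1 percentage points higher from compound 2 to compound 4 (within the scatter). Compound 4 is accordingly estimated at 6%, with a range from 0% to 20%.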

Compound 4, a percentage reported as inhibition, at one concentration (the size of the read-out at that concentration, not a potency): "not active" (no number reported)
No number was reported for compound 4; there is nothing to compare the estimate with.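

Going by these compounds alone, with no number reported for compound 4, no step from compound 2 to compound 4 can be read, and no measured evidence bears on this result. The compounds shown leave open how far butyl in place of phenylsulfonyl shifts the read-out.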